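This account rests on a few compounds, and the source may have more. Where it says the series, first, only, none or still open, it means among the compounds named here.

Working notes on the aryl ester series. Compound 1 `CC1=CC[C@H](C(C)C)c2cc(C)c(OC(=O)c3cccc(Cl)c3)cc21` and compound 2 `CC1=CC[C@H](C(C)C)c2cc(C)c(OC(=O)c3ccc(C(F)(F)F)cc3)cc21` differ in the substituent on the ester aryl ring and were both run in a functional assay on MCF7 cells (Homo sapiens) for antiproliferative activity, read by sulforhodamine B assay, with a stated time of 48 h, tested at 50 uM; on this read-out higher numbers stand for more inhibition at the one concentration tested (going by the name of the read-out) and lower numbers for less inhibition. In this assay compound 1 gives 40.4%, and in the same assay compound 2 gives 40.4%, level with compound 1 at the digits shown and within the usual scatter, so the two substituents are not distinguished on these numbers.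

The next compound, compound 3 `CC1=CC[C@H](C(C)C)c2cc(C)c(OC(=O)c3ccccc3)cc21`, removes the aryl substituent altogether. Relative to compound 2 the change is hydrogen in place of trifluoromethyl on an aromatic carbon. Among the measured compounds shown here, no measured pair isolates this step, so its size is not known from data; as the two aryl substituents examined so far give the same value, no step beyond the scatter is expected in this assay in either direction. Compound 3 is therefore expected to land near compound 2, at an estimated 38%, within 24% to 52%, corresponding to an expected step of a number 2.4 percentage points lower from compound 2 to compound 3 (within the scatter).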

Compound 3, a percentage reported as inhibition, at one concentration (the size of the read-out at that concentration, not a potency): 60.7%
Estimate against measurement, compound 3: 22.7 percentage points below; the whole stated range lies below it.
By their numbers in this assay, from the lowest: compounds 1 and 2 (each within the scatter of the next); then compound 3.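

In this assay the ester aryl ring without a substituent separates from both substituted esters: hydrogen in place of trifluoromethyl, para to a large group, gives a number 20.3 percentage points higher from compound 2 to compound 3 (beyond the scatter), and hydrogen in place of chloro on an aromatic carbon gives a number 20.3 percentage points higher from compound 1 to compound 3 (beyond the scatter). The level values of compound 1 and compound 2 gave no sign that a substituent on this ring matters, whereas compound 3 shows that each of these two substituents goes with less inhibition than hydrogen at the one concentration tested. Nothing available accounts for these steps.

On these data alone, it remains open whether an amine, a hydroxyl or a carboxylic acid on this ring would match compound 3 or fall back towards compound 1 and compound 2. As far as these compounds go, whether the steps hold at other concentrations also remains open.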